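The compounds below may be only part of what the source reports. "The series", "measured", "known", "first", "only" and "open" are said of these compounds alone.

Compounds 1, 2 and 3 share one core and differ only in the group attached on a saturated chain carbon bound to a sulfur. In a functional assay on PC-9 cells (Homo sapiens) for inhibition, read by MTT assay, with a stated time of 72 h (a lower number here means a stronger inhibitor, a higher number a weaker inhibitor), compound 1 `Cc1cc(Nc2cc(-c3ccccc3)[nH]n2)n2nc(SCc3c(Cl)cccc3Cl)nc2n1` gives 5180 nM, and compound 2 `Cc1cc(Nc2cc(-c3ccccc3)[nH]n2)n2nc(SCc3csc4ccccc34)nc2n1` gives 4420 nM; between them lies a 1.2-fold lower number from compound 1 to compound 2 (0.07 log units; within the scatter). Compound 3 `C=CCSc1nc2nc(C)cc(Nc3cc(-c4ccccc4)[nH]n3)n2n1` reaches only the limit of this assay, > 50000 nM, at the limit of > 50000 nM in this assay, at which 1 of the 3 values shown sits. On the numbers shown compound 3 therefore stands as the weakest of the three, since an at least 9.6-fold higher number from compound 1 to compound 3 (0.98 log units; beyond the scatter) and an at least 11-fold higher number from compound 2 to compound 3 (1.05 log units; beyond the scatter) both run beyond the scatter.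

Compound 4 `Cc1cc(Nc2cc(-c3ccccc3)[nH]n2)n2nc(SCC(=O)c3ccccc3)nc2n1` is not yet measured and differs from compound 3 as follows: benzoyl in place of vinyl on a saturated chain carbon bound to a sulfur. Because an at least 9.6-fold higher number from compound 1 to compound 3 (0.98 log units; beyond the scatter) and an at least 11-fold higher number from compound 2 to compound 3 (1.05 log units; beyond the scatter) show that losing an aromatic group on that carbon in favour of vinyl raised the number strongly, compound 4, which brings an aromatic ring back to that carbon, is expected to move in the opposite direction, by about an at least 5.5-fold lower number from compound 3 to compound 4 (0.74 log units; beyond the scatter). Among the measured compounds shown here, the carbonyl that enters has no counterpart among the measured compounds, so the expectation is loose. Compound 4 is estimated at 9000 nM in this assay, between 2500 nM and 45000 nM.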

Compound 4, half-maximal inhibitory concentration: 4450 nM
Compound 4: the middle estimate sits 2.0-fold (0.31 log units) above what was measured; the measured number falls inside the stated range.
By their numbers in this assay, from the lowest: compounds 2, 4 and 1 (each within the scatter of the next). At a limit, above all of these: compound 3.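

Putting benzoyl in place of vinyl on a saturated chain carbon bound to a sulfur gives, in this assay, an at least 11-fold lower number from compound 3 to compound 4 (1.05 log units; beyond the scatter). Compound 3 stands at a limit and not at a number, so the full size of that step is unknown: the limit of > 50000 nM in this assay, at which 1 of the 4 values shown sits.
With a 1.0-fold higher number from compound 2 to compound 4 (0.00 log units; within the scatter) and a 1.2-fold lower number from compound 1 to compound 4 (0.07 log units; within the scatter), the benzoyl compound cannot be told apart from the other two aromatic compounds, which shows that a carbonyl can enter here and that neither 2,6-dichlorophenyl nor 1-benzothiophen-3-yl is required for this level of inhibition.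

As far as these compounds go, whether an aromatic ring is needed at all stays open, since a saturated cyclohexyl ring or a longer alkyl chain on that carbon would test this. From the compounds shown here alone, it is also open whether an amine or a carboxylic acid on the benzoyl ring would move the number.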